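A few compounds are considered here, and "the series" means these few. Any claim that something is new, unique, unknown or untested is made for them only; others in the source may bear on it.

In a functional assay on T47D cells (Homo sapiens) for antiproliferative activity, read by MTT assay, with a stated time of 72 h (a lower number here means a stronger inhibitor, a higher number a weaker inhibitor), compound 1 `COc1cc(-c2nccn2C)cc(OC)c1OC` gives > 100000 nM, a limit and not a number. Compound 2 `CCCCn1ccnc1-c1cc(OC)c(OC)c(OC)c1` gives > 100000 nM, also a limit. Compound 3 `COc1cc(-c2nccn2-c2ccc(F)cc2)cc(OC)c1OC` stands at > 100000 nM, again only a limit. Compound 4 `COc1ccc(-n2ccnc2-c2cc(OC)c(OC)c(OC)c2)cc1` differs from compound 3 by methoxy in place of fluoro on an aromatic carbon, para to a large group. Two measured steps change the group on the aromatic nitrogen, a step that the two limits leave unreadable from compound 1 to compound 3 and a step that the two limits leave unreadable from compound 2 to compound 3, and neither gives a size or a direction. The expected change, an at least 2.0-fold lower number from compound 3 to compound 4 (0.30 log units; that floor lies within the scatter), is therefore a cautious guess leaning towards a slightly stronger inhibitor, and another limit may well appear. For compound 4 the estimate is 50000 nM, with an expected range from 3000 nM to 150000 nM.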

Compound 4, half-maximal inhibitory concentration: 1400 nM
Beside the measured number, compound 4's estimate is 36-fold (1.55 log units) above it; the measured number lies below the stated range.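

The earlier compounds shown here gave no readable steps in this assay, because they all sit at one limit: the limit of > 100000 nM in this assay, at which 3 of the 4 values shown sit. Methoxy in place of fluoro on an aromatic carbon, para to a large group, now gives an at least 71-fold lower number from compound 3 to compound 4 (1.85 log units; beyond the scatter), so this small change at this position separates a measurable inhibitor from a limit. The 4-methoxyphenyl group on the aromatic nitrogen likewise gives an at least 71-fold lower number from compound 2 to compound 4 (1.85 log units; beyond the scatter) in place of butyl and an at least 71-fold lower number from compound 1 to compound 4 (1.85 log units; beyond the scatter) in place of methyl.

As far as these compounds go, whether another group here, such as a hydroxyl or an amine, would serve as well stays open. From the compounds shown here alone, the true size of these steps also stays open: each one starts from a limit.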